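Swapping a Chloro for a Dimethylamino Ester Chain

A few compounds are considered here, and "the series" means these few. Any claim that something is new, unique, unknown or untested is made for them only; others in the source may bear on it.

Of the compounds shown here, three of a shared core have been tested in a functional assay on HeLa cells (Homo sapiens) for cytotoxicity, read by neutral red uptake, with a stated time of 3 days; a higher number here means a weaker inhibitor, a lower number a stronger inhibitor. Compound 1 `Nc1ccc(-c2cc(=O)c3c(N)c(F)c(O)c(F)c3o2)cc1F` carries a hydroxy on the core, and compound 2 `Nc1ccc(-c2cc(=O)c3c(N)c(F)c(Cl)c(F)c3o2)cc1F` carries a chloro in its place. In this assay compound 1 reaches only the limit of the measurement, > 100000 nM. Compound 2 likewise gives only a limit in this assay, > 100000 nM. Compound 3 `CCC(=O)OCc1c(F)c(N)c2c(=O)cc(-c3ccc(N)c(F)c3)oc2c1F` bears a (propanoyloxy)methyl there, and in this assay compound 3 gives a number, 69000 nM. Because two values sit at the limit of > 100000 nM in this assay, at which 2 of the 3 values shown sit, the step that the two limits leave unreadable from compound 1 to compound 2 cannot be sized, while an at least 1.4-fold lower number from compound 1 to compound 3 (0.16 log units; that floor lies within the scatter) and an at least 1.4-fold lower number from compound 2 to compound 3 (0.16 log units; that floor lies within the scatter) can be read only as floors.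

Compound 4 `CN(C)CCC(=O)OCc1c(F)c(N)c2c(=O)cc(-c3ccc(N)c(F)c3)oc2c1F` is not yet measured. Its change from compound 2 is (((2-(dimethylamino)ethyl)carbonyl)oxy)methyl in place of chloro on an aromatic carbon. For the measured compounds named here, the one measured step that bears on it is an at least 1.4-fold lower number from compound 2 to compound 3 (0.16 log units; that floor lies within the scatter), where a different ester-bearing chain replaced the same chloro. Compound 3, with 69000 nM, is the nearest guide. The step of an at least 1.4-fold lower number from compound 2 to compound 4 (0.15 log units; that floor lies within the scatter) is therefore expected to stay within the scatter of that floor. Compound 4 is estimated at 70000 nM, between 30000 nM and 150000 nM, with a fair chance that only a limit is reported again.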

Compound 4, half-maximal inhibitory concentration: 11000 nM
The estimate for compound 4 lay 6.4-fold (0.80 log units) above the measured number; the whole stated range lies above it.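

The clearest new reading comes from a single change, dimethylamino in place of hydrogen on a saturated chain carbon, two bonds along the chain from a carbonyl carbon: in this assay it gives a 6.3-fold lower number from compound 3 to compound 4 (0.80 log units; beyond the scatter). For the compounds shown here, at this position, then, the far end of the ester chain moves the number, which the earlier compounds could not show. Measured against the hydroxy and chloro groups, the full chain gives an at least 9.0-fold lower number from compound 1 to compound 4 (0.95 log units; beyond the scatter) and an at least 9.0-fold lower number from compound 2 to compound 4 (0.95 log units; beyond the scatter), and both are only floors because compounds 1 and 2 sit at a limit: the limit of > 100000 nM in this assay, at which 2 of the 4 values shown sit.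

The compounds shown leave open whether another amine at the chain end, such as a pyrrolidine or a morpholine, would act like dimethylamino. They also leave open what a longer chain, or an amide in place of the ester, would do.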